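The source may report more compounds than this note shows. Statements on the series, on what has been measured and on what is new or still open speak of the compounds shown alone.

Compound 1 `O=C(CCc1cccc2c1B(O)OC2)Nc1ccc(F)cc1` gives 720 nM
Compound 2 `O=C(CCc1cccc2c1B(O)OC2)Nc1ccc(Cl)cc1` gives 5000 nM
Compound 3 `O=C(CCc1cccc2c1B(O)OC2)Nc1ccc(Br)cc1` gives 9200 nM

In a functional assay on SK-OV-3 cells (Homo sapiens) for antiproliferative activity, read by MTT assay, with a stated time of 72 h (on this read-out higher numbers stand for weaker inhibition and lower numbers for stronger inhibition), compound 3 cannot be told apart from compound 2, and both carry higher numbers than compound 1. Compound 4 `C#Cc1ccc(NC(=O)CCc2cccc3c2B(O)OC3)cc1` has ethynyl in place of bromo on an aromatic carbon and keeps the rest of compound 3. Within the data shown here, no measured compound carries ethynyl, so the halogen steps are the only guide. Fluoro gave way to chloro with a 6.9-fold higher number from compound 1 to compound 2 (0.84 log units; beyond the scatter) and to bromo with a 13-fold higher number from compound 1 to compound 3 (1.11 log units; beyond the scatter) in a large jump. Chloro to bromo gave only a 1.8-fold higher number from compound 2 to compound 3 (0.26 log units; within the scatter) as its result. A step beyond the scatter is therefore not expected here. The expected change is a 1.5-fold lower number from compound 3 to compound 4 (0.19 log units; within the scatter) at most in size. For compound 4 the estimated value is 6000 nM with an expected range from 1800 nM to 18000 nM in this measurement.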

Compound 4, half-maximal inhibitory concentration: 6300 nM
The estimate for compound 4 lay 1.1-fold (0.02 log units) below the measured number, within the range that was stated.
By their numbers in this assay, from the lowest: compound 1; then compounds 2, 4 and 3 (each within the scatter of the next).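

In this assay, this position, para to a large group, now holds a group that is not a halogen, and ethynyl falls in with bromo (a 1.5-fold lower number from compound 3 to compound 4 (0.16 log units; within the scatter)) and with chloro (a 1.3-fold higher number from compound 2 to compound 4 (0.10 log units; within the scatter)). Fluoro remains apart from ethynyl as well (an 8.8-fold higher number from compound 1 to compound 4 (0.94 log units; beyond the scatter)), so the gap seen among the halogens also appears with a triple bond at this place. No measurement here explains why fluoro stands apart. Still open, going by these compounds, is whether an amine or a carboxylic acid at this position would match fluoro or the other three groups.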